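From a Methoxy Anchor to a Formylbenzyl Ether

This account rests on a few compounds, and the source may have more. Where it says the series, first, only, none or still open, it means among the compounds named here.

Compound 1 `COc1ccc(OCCOCCNC2CCCC2)cc1` was tested in a functional assay on SK-OV-3 cells (Homo sapiens) for inhibition, read by CCK-8 assay, with a stated time of 70 h (on this read-out lower numbers stand for stronger inhibition and higher numbers for weaker inhibition), where compound 1 gives 99100 nM. Its companion, compound 2 `c1ccc2cc(OCCOCCNC3CCCC3)ccc2c1`, gives 40600 nM in this assay. Of these two numbers, compound 1 stands at the higher one, and its gap to compound 2 lies beyond the scatter, so compound 2 is the stronger inhibitor of the pair.

Compound 3 `O=Cc1ccc(COc2ccc(OCCOCCNC3CCCC3)cc2)cc1` has not yet been measured. Relative to compound 1 it differs by 4-formylphenyl in place of hydrogen on a saturated chain carbon bound to an oxygen on an aromatic ring, so the methyl end of compound 1 becomes a 4-formylbenzyl group. For the measured compounds named here, no pair of measured compounds shares this change, so the data offer no direct precedent for its size. What the two measured values do show is that compound 2, at 40600 nM, sits below compound 1 at 99100 nM. On that basis a step of a 2.8-fold lower number from compound 1 to compound 3 (0.45 log units; beyond the scatter) is expected, toward a lower number. Compound 3 is therefore estimated at 35000 nM, with a likely range from 10000 nM to 120000 nM.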

Compound 3, half-maximal inhibitory concentration: 45000 nM
For compound 3 the middle estimate is 1.3-fold (0.11 log units) below the measured one; the measured number falls inside the stated range.
By their numbers in this assay, from the lowest: compounds 2 and 3 (each within the scatter of the next); then compound 1.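

For the compounds shown here, the change of the methyl end of compound 1 to a 4-formylbenzyl group gives the only step that can be read at this position: in this assay it amounts to a 2.2-fold lower number from compound 1 to compound 3 (0.34 log units; beyond the scatter), modest in size but beyond the scatter. The position, on a saturated chain carbon bound to an oxygen on an aromatic ring, therefore takes 4-formylphenyl in place of hydrogen, with its 8 heavy atoms and six-membered aromatic ring of carbon only, and the number still moves toward stronger inhibition rather than weaker. The data shown offer no measurement that accounts for this step, which rests on one pair of compounds alone.

On these data alone, what remains open is whether the step belongs to the added aromatic ring or to the formyl group, a question that a plain benzyl group or a 4-carboxybenzyl group at the same place would help to separate. Also open, as far as these compounds go, is whether a longer chain between the aromatic ring and the oxygen at this position, or an amine on the added ring, would carry the number further in either direction.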